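A few compounds are considered here, and "the series" means these few. Any claim that something is new, unique, unknown or untested is made for them only; others in the source may bear on it.

In an ADME assay on cells (Homo sapiens) for cytotoxicity, read by resazurin assay, with a stated time of 5 days (on this read-out higher numbers stand for lower toxicity in this test and lower numbers for higher toxicity in this test), compound 2 `O=S(=O)(Cc1nc(-c2cccnc2)c2sccc2n1)c1cccc(Cl)c1` gives > 50000 nM, and this value is a limit, not a measured number. Compound 1 `COc1ccc(-c2nc(CS(=O)(=O)c3cccc(Cl)c3)nc3ccsc23)cn1` gives > 10000 nM, which is also a limit. Compound 3 `O=S(=O)(Cc1nc(-c2ccoc2)c2sccc2n1)c1cccc(Cl)c1` has not yet been measured. It shares the core of compound 2 and differs from it in one place: furan-3-yl in place of pyridin-3-yl on an aromatic carbon. In words, furan-3-yl stands in place of pyridin-3-yl on an aromatic carbon, next to the ring nitrogen. Among the measured compounds shown here, only one measured step is available, a step that the two limits leave unreadable from compound 1 to compound 2. It concerns a different group and has no readable size, so it offers no real guide to this swap. No step beyond the usual scatter is therefore expected in this assay, and no direction can be named. The expected change is a number no higher from compound 2 to compound 3 (the limit leaves the size open). For compound 3, the estimated value is 50000 nM, with an expected range of 20000 nM to 100000 nM.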

Compound 3, half-maximal cytotoxic concentration: > 50000 nM
Compound 3 was reported as a limit; the forecaster's own chance of this, stated with the estimate: 65%; the middle value lies on the limit itself.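

In this assay compound 3 gives > 50000 nM, which is a limit. Compound 2 gives > 50000 nM, also a limit. Among the compounds shown here, no step between compound 1, compound 2 and compound 3 can be read from limits. The compounds shown leave open where each true value lies and whether swapping these groups changes it.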